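A few compounds are considered here, and "the series" means these few. Any claim that something is new, unique, unknown or untested is made for them only; others in the source may bear on it.

Three compounds sharing one core were tested in a functional assay on A549 cells (Homo sapiens) for cytotoxicity, read by MTT assay, with a stated time of 24 h; a lower number here means a stronger inhibitor, a higher number a weaker inhibitor. Compound 1, `C=CC1=C(C(=O)NCCCCC)C(c2ccc(Cl)c(Cl)c2)OC1`, gives in this assay only a limit of the measurement rather than a number, > 100000 nM. Compound 2, `C=CC1=C(C(=O)Nc2ccccc2)C(c2ccc(Cl)c(Cl)c2)OC1`, likewise gives only a limit, > 100000 nM. Compound 3, `C=CC1=C(C(=O)Nc2ccccc2)C(c2ccc(F)cc2)OC1`, also gives only a limit, > 100000 nM. The change from compound 2 to compound 1 is pentyl in place of phenyl on an amide-type nitrogen, and its step is a step that the two limits leave unreadable from compound 2 to compound 1. The change from compound 2 to compound 3 is 4-fluorophenyl in place of 3,4-dichlorophenyl on a saturated ring carbon, with the step that the two limits leave unreadable from compound 2 to compound 3. Neither step can be read because of the limit of > 100000 nM in this assay, at which 3 of the 3 values shown sit. Compound 4, `C=CC1=C(C(=O)NCCCCC)C(c2ccc(F)cc2)OC1`, is not yet measured; it differs from compound 3 by pentyl in place of phenyl on an amide-type nitrogen, the same change as from compound 2 to compound 1, now on the core of compound 3. The step from compound 3 to compound 4 is expected to be a step that the limit leaves unreadable from compound 3 to compound 4, resting on (the limit of > 100000 nM in this assay, at which 3 of the 3 values shown sit). In this assay compound 4 is estimated at 150000 nM, expected between 50000 nM and 600000 nM.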

Compound 4, half-maximal inhibitory concentration: > 100000 nM
Compound 4: no number, only a limit (the forecaster's own chance of this, stated with the estimate: 85%); the middle value is on the limit's open side.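

Compound 4, like compound 3, gives only a limit, so the step between them cannot be read: the limit of > 100000 nM in this assay, at which 4 of the 4 values shown sit. The compounds shown leave open whether pentyl in place of phenyl, or any other change among them, alters activity at all.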